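A few compounds are considered here, and "the series" means these few. Any claim that something is new, unique, unknown or untested is made for them only; others in the source may bear on it.

Three compounds have been measured so far in a functional assay on K562 cells (Homo sapiens) for cytotoxicity, read by trypan blue exclusion, with a stated time of 96 h; a higher number here means a weaker inhibitor, a lower number a stronger inhibitor:

Compound 1, `COc1ccccc1/C=C/S(=O)(=O)Cc1ccc(OC)c([N+](=O)[O-])c1`, gives 20000 nM.
Compound 2, `COc1ccc(CS(=O)(=O)/C=C/c2ccccc2OC)cc1N`, gives 7500 nM.
Compound 3, `COc1cc(OC)c(/C=C/S(=O)(=O)Cc2ccc(Br)c([N+](=O)[O-])c2)c(OC)c1`, gives 25000 nM.

Compound 1 and compound 2 differ in one place only, shown here:
amino in place of nitro on an aromatic carbon
That single change brought a 2.7-fold lower number from compound 1 to compound 2 (0.43 log units; beyond the scatter) in this assay. Compound 3 has a core unlike that of compound 1; the difference between the two cores is not broken down here. The number for compound 3 and the number for compound 1 lie within the usual scatter of each other, so no order can be read between them. The number for compound 2, on the other hand, is lower than that of compound 3 by more than the scatter.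

Compound 4, `COc1cc(OC)c(/C=C/S(=O)(=O)Cc2ccc(Br)c(N)c2)c(OC)c1`, has not yet been measured. It differs from compound 3 in one place:
amino in place of nitro on an aromatic carbon
Among the measured compounds shown here, this is the same kind of change as the one from compound 1 to compound 2, not the same change: in compound 1 the group sits ortho to a methoxy group, in compound 3 ortho to a bromo group, and the two cores themselves differ as well. For the measured compounds named here, because the only example of this change, a 2.7-fold lower number from compound 1 to compound 2 (0.43 log units; beyond the scatter), lowered the number by a modest amount, a similar step is expected from compound 3 to compound 4, that is a 2.8-fold lower number from compound 3 to compound 4 (0.44 log units; beyond the scatter). Compound 4 is therefore estimated at 9000 nM in this assay, with a likely range from 4000 nM to 20000 nM, resting on a single prior example.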

Compound 4, half-maximal inhibitory concentration: 750 nM
Estimate against measurement, compound 4: 12-fold (1.08 log units) above, outside the stated range (below it).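

In this assay, replacing nitro with amino on an aromatic carbon of compound 3 brought a 33-fold lower number from compound 3 to compound 4 (1.52 log units; beyond the scatter), a large step that turns one of the higher numbers in the set into the lowest. Set beside the earlier example, the same swap lowered the number on both cores, but by clearly different amounts: the same change on two cores in this assay, a 2.7-fold lower number (0.43 log units; beyond the scatter) from compound 1 to compound 2 and a 33-fold lower number (1.52 log units; beyond the scatter) from compound 3 to compound 4, 13-fold (1.10 log units) apart, beyond the scatter of two such steps In these two cases the direction of the change carried over from one core to the other and its size did not, so a step measured on one core cannot be copied as a number onto another; with only two pairs, and with cores that differ in more than one place, this shows neither a general rule nor which difference between the cores sets the size of the step.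

Going by these compounds, it remains open whether the lower number comes from the amino group itself or simply from the loss of nitro, a question that a plain hydrogen, a hydroxyl or an acetamide on that same aromatic carbon could help to settle. On these data alone, it also remains open how large the step would be on a core that differs from the core of compound 3 in a single place, for example with chloro in place of bromo.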